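A few compounds are considered here, and "the series" means these few. Any claim that something is new, unique, unknown or untested is made for them only; others in the source may bear on it.

Values in a functional assay on HEK293 cells (Homo sapiens) for cytotoxicity; on this read-out lower numbers stand for higher toxicity in this test and higher numbers for lower toxicity in this test (each one a limit, not a number)
compound 1 `COc1ccc([C@H]2CC(=O)N(Cc3cccc(C#N)c3)C2)cc1OC1CCCC1` gives > 10000 nM (limit)
compound 2 `COc1ccc([C@H]2CC(=O)N(c3cccc(N)c3C)C2)cc1OC1CCCC1` gives > 10000 nM (limit)
compound 3 `COc1ccc([C@H]2CC(=O)N(c3ccccc3C)C2)cc1OC1CCCC1` gives > 10000 nM (limit)

Compound 3 has only a limit, as do the other two compounds, so the series stands at the limit of > 10000 nM in this assay, at which 3 of the 3 values shown sit (no ranking is possible). Within the data shown here, compound 4 `COc1ccc([C@H]2CC(=O)N(c3ccccn3)C2)cc1OC1CCCC1` carries pyridin-2-yl in place of 2-methylphenyl on an amide-type nitrogen in a ring (its only difference from compound 3). Two measured changes fall on that same nitrogen, namely a step that the two limits leave unreadable from compound 1 to compound 3 and a step that the two limits leave unreadable from compound 1 to compound 2 (neither has a readable size). The third, a step that the two limits leave unreadable from compound 2 to compound 3 (also of unreadable size), lies on an aromatic carbon. These steps set no size for the new change, and all three compounds remain at the limit. No step beyond the usual scatter and no direction is therefore expected, giving an expected step that the limit leaves unreadable from compound 3 to compound 4 (an estimate only). In this assay the estimate for compound 4 is 20000 nM (expected range 10000 nM to 40000 nM), and another report as a limit is the likeliest outcome.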

Compound 4, half-maximal cytotoxic concentration: > 10000 nM
Compound 4: no number, only a limit; the forecaster's own chance of this, stated with the estimate: 90%; the middle value does not contradict the limit.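

In this assay compound 4 gives > 10000 nM as a limit. Among these compounds, no step from compound 1, compound 2 or compound 3 to compound 4 can be read, and the series sits at one value: the limit of > 10000 nM in this assay, at which 4 of the 4 values shown sit. The compounds shown leave open whether any change on the amide-type nitrogen alters toxicity in this assay at all.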